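The source may hold more compounds than are shown below. What is called first, only, known or untested is meant among the compounds shown, and "the series" means these compounds.

In a functional assay on MCF7 cells (Homo sapiens) for antiproliferative activity, read by MTT assay (a higher number here means a weaker inhibitor, a lower number a stronger inhibitor), compound 1 `CCCC/C=C\CCCCCCCCCc1cc(=O)c2c(O)c(C)c(OCOC)cc2o1` gives only a limit, > 67200 nM. Compound 2 `CCCC/C=C\CCCCCCCCCc1cc(=O)c2c(O)c(C)c(OCOC)c(C)c2o1` also gives only a limit, > 67200 nM. Compound 3 `CC/C=C\C/C=C\C/C=C\CCCCCCCc1cc(=O)c2c(O)c(C)c(OCOC)cc2o1` differs from compound 1 in its chain: a group of 10 heavy atoms (10 carbon; no ring) in place of a group of 8 heavy atoms (8 carbon; no ring), on a saturated chain carbon, seven bonds along the chain from an aromatic carbon. Among the compounds with values here, no measured step covers this change, and the only one available, a step that the two limits leave unreadable from compound 1 to compound 2, has no readable size. Compound 1 thus stands at the limit of > 67200 nM in this assay, at which 2 of the 2 values shown sit, and the expectation rests on that alone. The expected step is a step that the limit leaves unreadable from compound 1 to compound 3, with no change expected beyond the scatter. The estimate for compound 3 is 70000 nM, with an expected range of 25000 nM to 150000 nM.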

Compound 3, half-maximal inhibitory concentration: 17500 nM
For compound 3 the middle estimate is 4.0-fold (0.60 log units) above the measured one, outside the stated range (below it).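

In this assay, within the data shown here, the chain is the first place on the shared core where a change gives a readable result: the oct-3-en-1-yl group gives way to a group with 10 carbon and 3 double bonds, with an at least 3.8-fold lower number from compound 1 to compound 3 (0.58 log units; beyond the scatter). The step from compound 1 to compound 2 cannot be read, so the aromatic methyl gave no such result. Compound 3 alone has a number rather than a limit: the limit of > 67200 nM in this assay, at which 2 of the 3 values shown sit.

Carbon count and double bonds change together here, so their shares stay unseparated. From the compounds shown here alone, a saturated decyl group in the same place would bear on this, and how the aromatic methyl acts with the new chain remains open.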